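Three limits and a halogen swap in dog microsomes

The compounds below may be only part of what the source reports. "The series", "measured", "known", "first", "only" and "open" are said of these compounds alone.

Measured in an ADME assay on microsomes from liver (Canis lupus familiaris) for metabolic stability; a higher number here means that the compound lasts longer, a lower number that the compound disappears faster:
- compound 1 `Nc1nc(NCCNc2ncc(-c3ncc[nH]3)c(-c3ccccc3Br)n2)ccc1[N+](=O)[O-]`: > 0.5 h (a limit of the assay)
- compound 2 `Nc1nc(NCCNc2ncc(-c3ncc[nH]3)c(-c3cc(F)c(F)cc3F)n2)ccc1[N+](=O)[O-]`: > 0.5 h (a limit of the assay)
- compound 3 `Nc1nc(NCCNc2ncc(-c3ncc[nH]3)c(-c3ccc(F)cc3Cl)n2)ccc1[N+](=O)[O-]`: > 0.5 h (a limit of the assay)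

Compound 3 stands at > 0.5 h, which is a limit and not a number. The same holds for its two neighbours, and the series as a whole sits at the limit of > 0.5 h in this assay, at which 3 of the 3 values shown sit. The change now in view leads to compound 4 `Nc1nc(NCCNc2ncc(-c3ncc[nH]3)c(-c3cc(F)c(Cl)cc3Cl)n2)ccc1[N+](=O)[O-]`, where 2,4-dichloro-5-fluorophenyl takes the place of 2-chloro-4-fluorophenyl on an aromatic carbon, next to the ring nitrogen: 2,4-dichloro-5-fluorophenyl in place of 2-chloro-4-fluorophenyl on an aromatic carbon.

Going by the values given here, three measured steps bear on this change, each an exchange of the same aryl group: a step that the two limits leave unreadable from compound 1 to compound 2, a step that the two limits leave unreadable from compound 1 to compound 3 and a step that the two limits leave unreadable from compound 2 to compound 3. None of them has a readable size, so they offer no direction for this assay. Among the compounds with values here, they show only that these three aryl groups all give the same limit. The most likely outcome is therefore another limit, with no readable change. The step expected on this basis is a step that the limit leaves unreadable from compound 3 to compound 4. For compound 4 the estimated half-life is 0.7 h, with an expected range from 0.4 h to 1.5 h.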

Compound 4, half-life: > 0.5 h
Compound 4: a limit, no number; the forecaster's own chance of this, stated with the estimate: 85%; the middle value lies beyond the limit too.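

In this assay compound 4 gives > 0.5 h, which is a limit of the assay and not a number. Its steps from compound 1, compound 2 and compound 3 cannot be read, and the series shares one limit: the limit of > 0.5 h in this assay, at which 4 of the 4 values shown sit. The compounds shown leave open how long each actually lasts and whether these aryl groups differ at all.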